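Ester-bearing chain in place of ethoxy: compound 3

The source may report more compounds than this note shows. Statements on the series, on what has been measured and on what is new or still open speak of the compounds shown alone.

Compound 1 `CCC(C)CNCCN(C(=O)[C@@H]1C[C@H]1c1ccccc1)c1ccc(-c2ccccc2)cc1` and compound 2 `CCOc1ccc(-c2ccc(N(C[C@@H](N)[C@@H](C)CC)C(=O)[C@@H]3C[C@H]3c3ccccc3)cc2)cc1` share one core. Within the data shown here, in a functional assay for agonist activity at G protein-coupled receptor 88 (Homo sapiens), read by HTRF and cAMP accumulation (on this read-out higher numbers stand for an effect only at larger amounts of compound and lower numbers for an effect already at smaller amounts), compound 1 gives 4.7 nM, and compound 2 gives 90 nM, the higher of the two numbers measured so far, with the gap to compound 1 beyond the scatter. Compound 3 `CC[C@H](C)[C@H](N)CN(C(=O)[C@@H]1C[C@H]1c1ccccc1)c1ccc(-c2ccc(CCC(=O)OC)cc2)cc1` is not yet measured; it differs from compound 2 by 2-(methoxycarbonyl)ethyl in place of ethoxy on an aromatic carbon. Among the measured compounds shown here, no measured pair isolates this change, so its direction is open. The step from compound 2 to compound 3 is expected to be small, as a 1.1-fold higher number from compound 2 to compound 3 (0.05 log units; within the scatter), within or near the scatter. For compound 3 the estimate in this assay is 100 nM, with a range from 30 nM to 350 nM.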

Compound 3, half-maximal effective concentration: 110 nM
Beside the measured number, compound 3's estimate is 1.1-fold (0.04 log units) below it, and the stated range covers the measured number.
By their numbers in this assay, from the lowest: compound 1; then compounds 2 and 3 (each within the scatter of the next).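

At this aromatic carbon, para to a large group, 2-(methoxycarbonyl)ethyl in place of ethoxy gives a 1.2-fold higher number from compound 2 to compound 3 (0.09 log units; within the scatter) in this assay. Among these compounds, this is the first pair to isolate the position, and it shows that the ethoxy oxygen directly on the ring and the shorter chain can be replaced by the ester-bearing chain without a step beyond the scatter. No measurement here offers an explanation for this result.

Open, as far as these compounds go, is whether a carboxylic acid at the end of this chain, or an amine in its place, would stay within the scatter of compound 2.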